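The source may report more compounds than this note shows. Statements on the series, on what has been measured and on what is new or still open speak of the compounds shown alone.

Going by the values given here, compound 2 `COC(=O)[C@@H]1CCCC[C@@H]1c1ccc(C(C)(C)C)cc1` is the weaker of the two compounds measured so far in an assay on COS-1 cells for displacement of a labelled ligand from sodium-dependent dopamine transporter (Homo sapiens); a lower number here means a stronger inhibitor, a higher number a weaker inhibitor: in this assay compound 2 gives 766000 nM, while compound 1 `COC(=O)C1=C(c2ccccc2)CCCC1` gives 630000 nM, and the gap between these two numbers lies within the scatter of the method, so no order can be read from them. Compound 3 `COC(=O)[C@@H]1CCCC[C@@H]1c1ccccc1` is the next compound to be examined. It is obtained from compound 2 by the exchange (hydrogen in place of tert-butyl on an aromatic carbon), that is, hydrogen in place of tert-butyl on an aromatic carbon of a six-membered aromatic ring of carbon only. Among the compounds with values here, no measured pair in this set tracks that exchange, so the expected size of the step is only an estimate. Compound 3 shares its phenyl-bearing ring with compound 1 and its saturated core with compound 2, and both give very high numbers in this assay; compound 3 is therefore expected to land close to them, with the step of a 1.4-fold lower number from compound 2 to compound 3 (0.14 log units; within the scatter) estimated to be small and within the scatter. The estimate for compound 3 in this assay is 550000 nM, with a range from 150000 nM to 2000000 nM.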

Compound 3, inhibition constant: 975000 nM
For compound 3 the middle estimate is 1.8-fold (0.25 log units) below the measured one; the measured number falls inside the stated range.
By their numbers in this assay, from the lowest: compounds 1, 2 and 3 (each within the scatter of the next).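

In this assay the exchange of tert-butyl for hydrogen on an aromatic carbon, para to a large group, gives a 1.3-fold higher number from compound 2 to compound 3 (0.10 log units; within the scatter) and stays within the scatter. Going by these compounds alone, this is the first pair in the set that differs in one place, and it shows that tert-butyl and hydrogen at this position cannot be told apart in this read-out, with both compounds still giving very high numbers. No measurement shown offers a reason for this result.

The compounds shown leave open whether any other group at this position, such as an amine, a carboxylic acid or a longer chain, would give a number that can be separated from those of compound 2 and compound 3. They also leave open whether an amine in place of the methyl ester on the shared core would give a lower number.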